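Pyridine for Phenyl on a Boronic Acid Hydrazone Series

The source may hold more compounds than are shown below. What is called first, only, known or untested is meant among the compounds shown, and "the series" means these compounds.

Three compounds have been measured in a functional assay on B16 cells (Mus musculus) for inhibition; on this read-out lower numbers stand for stronger inhibition and higher numbers for weaker inhibition:

Compound 1, `CC(C)CN(NC(=O)OCc1ccccc1)C(=O)CN(Cc1ccccc1)/N=C/c1cccc(B(O)O)c1`: 20400 nM
Compound 2, `CC(C)CN(CC(=O)N(Cc1ccccc1)NC(=O)OCc1ccccc1)/N=C/c1cccc(B(O)O)c1`: 20500 nM
Compound 3, `CC(C)CN(CC(=O)N(Cc1cccnc1)NC(=O)OCc1ccccc1)/N=C/c1cccc(B(O)O)c1`: 21100 nM

Compounds 1 and 2 are built from the same atoms joined in a different way; the difference between the two cores is not broken down here. Their values in this assay lie within the scatter of each other, so nothing separates them.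

Compound 3 comes from compound 2 by a single change, (pyridin-3-yl in place of phenyl on a saturated chain carbon bound to an amide-type nitrogen). The step of a 1.0-fold higher number from compound 2 to compound 3 (0.01 log units; within the scatter) is within the scatter, so the change left the read-out essentially unmoved.

Compound 4, `CC(C)CN(NC(=O)OCc1ccccc1)C(=O)CN(Cc1cccnc1)/N=C/c1cccc(B(O)O)c1`, is not yet measured. It comes from compound 1 by pyridin-3-yl in place of phenyl on a saturated chain carbon bound to an amine nitrogen. Among the measured compounds shown here, this is the same kind of change as the one from compound 2 to compound 3, but not the same: in one case the carbon carrying the ring is bound to an amide-type nitrogen, in the other to an amine nitrogen.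

For the measured compounds named here, with only one measured example of this kind of change, the expectation rests on it alone. The step from compound 1 to compound 4 is expected to be a 1.0-fold higher number from compound 1 to compound 4 (0.01 log units; within the scatter), close to the earlier one, because a 1.0-fold higher number from compound 2 to compound 3 (0.01 log units; within the scatter) was within the scatter. Compound 4 is therefore estimated at 21000 nM in this assay, expected to lie between 12000 nM and 38000 nM.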

Compound 4, half-maximal inhibitory concentration: 74900 nM
The estimate for compound 4 lay 3.6-fold (0.55 log units) below the measured number; measured number above the stated range.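

In this assay, pyridin-3-yl in place of phenyl did not act alike on the two cores. On the core of compound 1, where the ring sits on a saturated chain carbon bound to an amine nitrogen, the change gave a 3.7-fold higher number from compound 1 to compound 4 (0.56 log units; beyond the scatter) and so weakened inhibition, while on the core of compound 2 it left the read-out essentially unmoved, and the two steps clearly differ: the same change on two cores in this assay, a 1.0-fold higher number (0.01 log units; within the scatter) from compound 2 to compound 3 and a 3.7-fold higher number (0.56 log units; beyond the scatter) from compound 1 to compound 4, 3.6-fold (0.55 log units) apart, beyond the scatter of two such steps.
This shows that a swap that is silent on one core cannot simply be assumed to be silent on the other in this series, but it rests on a single pair of compounds for each core and does not show why the two cores part ways or how the same swap would behave on any further core.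

The compounds shown leave open whether the loss on the core of compound 1 is particular to pyridin-3-yl or would also appear with pyridin-2-yl or pyridin-4-yl. They also leave open whether a phenyl ring carrying a methoxy group or a carboxylic acid would separate the two cores in the same way.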